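Removing a Fluorine from a Weak Vitamin D Receptor Ligand

The source may report more compounds than this note shows. Statements on the series, on what has been measured and on what is new or still open speak of the compounds shown alone.

Measured so far:
compound 1, `CN(CC(=O)N1CCN(c2ccc(F)cc2)CC1)C(=O)c1ccc(S(C)(=O)=O)c([N+](=O)[O-])c1`: > 60000 nM
compound 2, `CC1CCN(C(=O)CCNC(=O)c2ccc(S(C)(=O)=O)c([N+](=O)[O-])c2)CC1`: > 60000 nM

Of the compounds shown here, two have been measured in an assay on isolated protein for inhibition of vitamin D3 receptor (Homo sapiens), read by fluorescence polarization; a lower number here means a stronger inhibitor, a higher number a weaker inhibitor. In this assay compound 1 `CN(CC(=O)N1CCN(c2ccc(F)cc2)CC1)C(=O)c1ccc(S(C)(=O)=O)c([N+](=O)[O-])c1` gives > 60000 nM, which is a limit of the assay and not a number. Compound 2 `CC1CCN(C(=O)CCNC(=O)c2ccc(S(C)(=O)=O)c([N+](=O)[O-])c2)CC1` gives > 60000 nM in this assay, again only a limit. Within the data shown here, compound 1 therefore stands at the limit of > 60000 nM in this assay, at which 2 of the 2 values shown sit, and no compound of this series has yet given a real number.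

The next compound, compound 3 `CN(CC(=O)N1CCN(c2ccccc2)CC1)C(=O)c1ccc(S(C)(=O)=O)c([N+](=O)[O-])c1`, differs from compound 1 in one place: hydrogen in place of fluoro on an aromatic carbon. Among the measured compounds shown here, no step between measured compounds is available to judge this change, and both measured values are limits. With compound 1 at > 60000 nM, the change is expected to give a step that the limit leaves unreadable from compound 1 to compound 3, nothing beyond the scatter and most likely another limit. Compound 3 is estimated to give 90000 nM in this assay. The expected range for compound 3 runs from 40000 nM to 300000 nM.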

Compound 3, half-maximal inhibitory concentration: > 60000 nM
Compound 3: no number, only a limit; the forecaster's own chance of this, stated with the estimate: 90%; the middle value lies beyond the limit too.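

Compound 3 gives > 60000 nM in this assay, which is a limit of the assay and not a number. Among these compounds, compound 1 also stands at a limit, so no step from compound 1 to compound 3 can be read, and the change from 4-fluorophenyl to phenyl has no readable size. The compounds shown leave open whether any member of this series gives a real number: the limit of > 60000 nM in this assay, at which 3 of the 3 values shown sit.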